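The compounds below may be only part of what the source reports. "The series", "measured", "known", "first", "only" and "open" are said of these compounds alone.

Compound 1, `N=C(N)N/N=C/c1c(-c2cccs2)nc2sccn12`: in a functional assay on cells (Melanoma cell, Homo sapiens) for inhibition (on this read-out lower numbers stand for stronger inhibition of growth and higher numbers for weaker inhibition of growth), compound 1 gives 28800 nM.
Compound 2, `Cc1cc(-c2nc3sccn3c2/C=N/NC(=N)N)c(C)s1`: compound 2 gives 30900 nM.
Compound 3, `Cc1cc(-c2nc3n(c2/C=N/NC(=N)N)CCS3)c(C)s1`: compound 3 gives 29500 nM.

Compound 1 and compound 2 share one core and differ in a single group: thiophen-2-yl in place of 2,5-dimethylthiophen-3-yl on an aromatic carbon. In this assay that change gave a 1.1-fold lower number from compound 2 to compound 1 (0.03 log units; within the scatter). Compound 3 is built on a second core; how its core differs from the core of compound 2 is not broken down here, and the values of compound 2 and compound 3 lie within the usual scatter of each other.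

Compound 4, `N=C(N)N/N=C/c1c(-c2cccs2)nc2n1CCS2`, has not yet been measured. It stands to compound 3 as compound 1 stands to compound 2: thiophen-2-yl in place of 2,5-dimethylthiophen-3-yl on an aromatic carbon. This is the same kind of change rather than the same change, since in compound 3 the carbon that carries the group is also two ring bonds from two ring atoms that each bear a fused ring.

For compound 4 the expected step is a 1.1-fold lower number from compound 3 to compound 4 (0.02 log units; within the scatter), set beside the earlier one and resting on the small size of a 1.1-fold lower number from compound 2 to compound 1 (0.03 log units; within the scatter). The estimate for compound 4 is 28000 nM, expected to fall between 14000 nM and 56000 nM.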

Compound 4, concentration for total growth inhibition: 38000 nM
The estimate for compound 4 lay 1.4-fold (0.13 log units) below the measured number, and the stated range covers the measured number.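

In this assay, putting thiophen-2-yl in place of 2,5-dimethylthiophen-3-yl on the second core gives a 1.3-fold higher number from compound 3 to compound 4 (0.11 log units; within the scatter). Set beside the same swap on the first core, this step shows no real difference between the two cores: the same change on two cores in this assay, a 1.1-fold lower number (0.03 log units; within the scatter) from compound 2 to compound 1 and a 1.3-fold higher number (0.11 log units; within the scatter) from compound 3 to compound 4, 1.4-fold (0.14 log units) apart, within the scatter of two such steps. The change therefore carries over only in a modest sense: on both cores it leaves the number within the scatter, but with steps this small the comparison cannot show that a change with a clear effect on one core would have the same effect on the other.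

The compounds shown carry only these two thiophene groups on that aromatic carbon, so it remains open whether a different group there, such as a plain phenyl ring, an amine or a carboxylic acid, would move the number beyond the scatter. If one did, comparing that step on both cores would be a far stronger test of whether a change carries from one core to the other.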